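The source may report more compounds than this note shows. Statements on the series, on what has been measured and on what is new or still open speak of the compounds shown alone.

Values in a functional assay on A549 cells (Homo sapiens) for antiproliferative activity, read by MTT assay (on this read-out lower numbers stand for stronger inhibition and higher numbers for weaker inhibition), so far
- compound 1 `COc1cc2c(Oc3ccc(NC(=O)Nc4ccc(OC(F)(F)F)cc4)cc3)ccnc2cc1OCCCCCCC(=O)NO` gives 3130 nM
- compound 2 `COc1cc2c(Oc3ccc(NC(=O)Nc4ccc(C)cc4C)cc3)ccnc2cc1OCCCCCCC(=O)NO` gives 5490 nM
- compound 3 `COc1cc2c(Oc3ccc(NC(=O)N/N=C/c4ccccc4F)cc3)ccnc2cc1OCCCCCCC(=O)NO` gives 7780 nM

Compound 2 at 5490 nM lies in the middle of these three numbers, but it is not clearly separated from either neighbour. The steps of a 1.8-fold higher number from compound 1 to compound 2 (0.24 log units; within the scatter) and a 1.4-fold higher number from compound 2 to compound 3 (0.15 log units; within the scatter) both stay within the scatter. For the measured compounds named here, only the step of a 2.5-fold higher number from compound 1 to compound 3 (0.40 log units; beyond the scatter) goes beyond it, and modestly.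

Compound 4 `COc1cc2c(Oc3ccc(NC(=O)NNC(=O)c4cccc(C)c4)cc3)ccnc2cc1OCCCCCCC(=O)NO` is not yet measured. It carries ((3-methylphenyl)carbonyl)amino in place of 2,4-dimethylphenyl on an amide-type nitrogen and otherwise matches compound 2.

The closest measured change is the step of a 1.4-fold higher number from compound 2 to compound 3 (0.15 log units; within the scatter), where the entering group also places a nitrogen on that amide-type nitrogen. Going by the values given here, no measured compound carries the carbonyl of compound 4, so this guide is loose and the range must stay wide. With compound 3 at 7780 nM as the nearest reference, no step beyond the scatter is expected in this assay for compound 4, only a slight lean toward a higher number.

The estimated step is a 1.3-fold higher number from compound 2 to compound 4 (0.11 log units; within the scatter) and it is expected to stay within the scatter.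

The expected value for compound 4 is 7000 nM with an estimated range from 3000 nM to 16000 nM in this read-out.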

Compound 4, half-maximal inhibitory concentration: 8190 nM
Compound 4: middle estimate off by 1.2-fold (0.07 log units), on the low side; measured number inside the range.
By their numbers in this assay, from the lowest: compounds 1, 2, 3 and 4 (each within the scatter of the next, the first and the last beyond it).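

In this assay, the swap of 2,4-dimethylphenyl for ((3-methylphenyl)carbonyl)amino on the amide-type nitrogen gives a 1.5-fold higher number from compound 2 to compound 4 (0.17 log units; within the scatter) and so shows that an entering group with a carbonyl, one hydrogen-bond donor and one hydrogen-bond acceptor does not move the number beyond the scatter at this place. The two groups that put a nitrogen on the amide-type nitrogen read alike, with a 1.1-fold higher number from compound 3 to compound 4 (0.02 log units; within the scatter) as their step, and among the steps to compound 4 the only one beyond the scatter is a 2.6-fold higher number from compound 1 to compound 4 (0.42 log units; beyond the scatter), a modest one that sets compound 4 apart from the 4-(trifluoromethoxy)phenyl group of compound 1. Nothing available explains why these groups read as they do.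

Still open, as far as these compounds go, is whether a pyridine ring or a morpholine on the amide-type nitrogen would give a number clearly lower than that of compound 1, which would show whether this place can drive the read-out at all. Also open, from the compounds shown here alone, is whether a carboxylic acid or a longer chain at the hydroxamic acid end would shift all four compounds together.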